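Dropping the methoxy: from compound 2 to compound 3

The compounds below may be only part of what the source reports. "The series", "measured", "known", "first", "only" and "open" are said of these compounds alone.

Compound 1 `O=C(O)CCc1ccc(C#Cc2ccnc(Cl)c2)cc1`: in an in vitro functional assay on 1321-N1 cells for agonist activity at Free fatty acid receptor 1 (Homo sapiens), read by fluorescence, spectrophotometry and calcium flux (a lower number here means that less compound is needed, a higher number that more compound is needed for the effect), compound 1 gives 295 nM.
Compound 2 `COc1cc(C#Cc2ccc(CCC(=O)O)cc2)ccn1`: in this assay compound 2 gives 525 nM.
Compound 3 `O=C(O)CCc1ccc(C#Cc2ccncc2)cc1`: not yet measured.

Among the measured compounds shown here, compound 2 stands highest of the two numbers measured so far, yet the step of a 1.8-fold higher number from compound 1 to compound 2 (0.25 log units; within the scatter) lies within the scatter. Compound 3 differs from compound 2 by hydrogen in place of methoxy on an aromatic carbon. For the measured compounds named here, the only measured step that bears on this change is a 1.8-fold higher number from compound 1 to compound 2 (0.25 log units; within the scatter), a swap on the same aromatic carbon that left the number essentially unmoved. The step to compound 3 is therefore expected to be small, a 1.1-fold lower number from compound 2 to compound 3 (0.02 log units; within the scatter), with no clear direction beyond the scatter. Compound 3 is estimated at 500 nM, between 200 nM and 1500 nM.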

Compound 3, half-maximal effective concentration: 4070 nM
Compound 3: middle estimate off by 8.1-fold (0.91 log units), on the low side; the measured number lies above the stated range.
By their numbers in this assay, from the lowest: compounds 1 and 2 (each within the scatter of the next); then compound 3.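

In this assay the aromatic carbon next to the ring nitrogen proves not to be indifferent: what matters is less which of the two groups sits there than whether one sits there at all. Hydrogen in place of methoxy gives a 7.8-fold higher number from compound 2 to compound 3 (0.89 log units; beyond the scatter) and hydrogen in place of chloro gives a 14-fold higher number from compound 1 to compound 3 (1.14 log units; beyond the scatter) while the chloro and methoxy compounds lie within the scatter of each other. Nothing available accounts for this result. Still open, going by these compounds, is how far this holds for other groups on that carbon, such as fluoro, methyl or an amine.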